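The compounds below may be only part of what the source reports. "The series", "measured", "known", "first", "only" and "open" are said of these compounds alone.

In a functional assay on G-361 cells (Homo sapiens) for antiproliferative activity, with a stated time of 72 h (a higher number here means a weaker inhibitor, a lower number a stronger inhibitor), compound 2 `OC[C@H]1O[C@@H](n2cnc3c(NCc4ccc(F)cc4Cl)ncnc32)[C@H](O)[C@@H]1O` gives > 166000 nM, which is a limit and not a number. Compound 1 `OC[C@H]1O[C@@H](n2cnc3c(NCc4ccc(F)c(F)c4F)ncnc32)[C@H](O)[C@@H]1O` gives > 166000 nM, which is also a limit. For the measured compounds named here, compound 2 therefore has no exact position on this scale, and the same holds for its only measured neighbour: the limit of > 166000 nM in this assay, at which 2 of the 2 values shown sit.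

Compound 3 `OC[C@H]1O[C@@H](n2cnc3c(NCc4ccc(F)c(Cl)c4)ncnc32)[C@H](O)[C@@H]1O` keeps the same atoms but joins them differently: 3-chloro-4-fluorophenyl in place of 2-chloro-4-fluorophenyl on a saturated chain carbon bound to a nitrogen on an aromatic ring. In words, 3-chloro-4-fluorophenyl takes the place of 2-chloro-4-fluorophenyl.

Going by the values given here, the one measured step that bears on this change is a step that the two limits leave unreadable from compound 1 to compound 2, so it offers no size to carry over. Any forecast is therefore loose, and a second limit in this assay would be no surprise.

The expected change is an at least 2.0-fold lower number from compound 2 to compound 3 (0.31 log units; beyond the scatter), an estimate that leans toward a stronger inhibitor. Compound 3 is expected to give about 80000 nM, with an estimated range of 5000 nM to 166000 nM.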

Compound 3, half-maximal inhibitory concentration: > 166000 nM
Compound 3: a limit, no number; the forecaster's own chance of this, stated with the estimate: 60%; middle value at least 2.0-fold (0.31 log units) from the limit.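

For the compounds shown here, compound 3, like compound 1 and compound 2, gives only a limit and not a number, so no step among the three can be read: the limit of > 166000 nM in this assay, at which 3 of the 3 values shown sit. As far as these compounds go, how strongly each of the three inhibits, and whether 3-chloro-4-fluorophenyl differs from 2-chloro-4-fluorophenyl at all, stays open.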